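A few compounds are considered here, and "the series" means these few. Any claim that something is new, unique, unknown or untested is made for them only; others in the source may bear on it.

Measured compounds in an assay for inhibition of Polyunsaturated fatty acid 5-lipoxygenase (Homo sapiens), read by HPLC, with stated times of 15 min and 10 min; on this read-out lower numbers stand for stronger inhibition and higher numbers for weaker inhibition:
- compound 1, `C[C@H](C#Cc1cccc(C(=O)NCCC(c2ccc(F)cc2)c2ccc(C(F)(F)F)cc2)c1)N(O)C(N)=O`: 220 nM
- compound 2, `C[C@H](C#Cc1cccc(C(=O)NCC[C@@H](c2ccc(F)cc2)c2ccc(C(F)(F)F)cc2)c1)N(O)C(N)=O`: 160 nM
- compound 3, `COc1ccc(CNC(=O)c2cccc(C#CC(C)N(O)C(N)=O)c2)c(C(F)(F)F)c1`: 1700 nM

Compound 2 holds the lowest number of the three in this assay; compound 1 sits nearest to it, within the scatter, while compound 3 lies furthest, beyond the scatter. Compound 1 and compound 2 share every atom and bond, and the one place where they differ is a stereocentre at a saturated chain carbon, drawn without a configuration in compound 1 and R in compound 2 (the fact that one of compounds 1 and 2 is drawn with a defined configuration and the other without, at the place where they differ); the step of a 1.4-fold lower number from compound 1 to compound 2 (0.14 log units; within the scatter) is small.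

Compound 4, `C[C@H](C#Cc1cccc(C(=O)NCC[C@H](c2ccc(F)cc2)c2ccc(C(F)(F)F)cc2)c1)N(O)C(N)=O`, is not yet measured. It differs from compound 2 only in configuration as drawn: the two compounds have the same atoms and bonds and differ only in configuration as drawn: 1 of 2 stereo elements differ; a stereocentre at a saturated chain carbon is drawn R in compound 2 and S in compound 4. Among the measured compounds shown here, the one measured step that bears on this change is the step from the undefined form to the R form, a 1.4-fold lower number from compound 1 to compound 2 (0.14 log units; within the scatter), which stays within the scatter. Since compound 1 carries the stereocentre without a defined configuration, its number can be read as a blend of the R and S forms, and that blend sits close to compound 2. The S form alone is therefore expected to sit somewhat higher than compound 2, though the measured step is too small to fix the size with confidence; the expected step of a 2.0-fold higher number from compound 2 to compound 4 (0.30 log units; within the scatter) is modest. In this assay compound 4 is expected to give 320 nM, with a range from 130 nM to 900 nM.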

Compound 4, half-maximal inhibitory concentration: 230 nM
For compound 4 the middle estimate is 1.4-fold (0.14 log units) above the measured one, and the stated range covers the measured number.
By their numbers in this assay, from the lowest: compounds 2, 1 and 4 (each within the scatter of the next); then compound 3.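

Among the compounds shown here, compound 4 supplies the S form, so the R and S forms at this saturated chain carbon can now be compared directly in this assay (a 1.4-fold higher number from compound 2 to compound 4 (0.16 log units; within the scatter)), where the earlier compounds offered only the R form against the undefined form. This comparison is a clean test of the configuration at that carbon because nothing else separates the pair: the fact that compounds 2 and 4 differ only in the configuration as drawn. The undefined form also stays within the scatter of the S form (a 1.0-fold higher number from compound 1 to compound 4 (0.02 log units; within the scatter)), so in this assay the read-out cannot tell the R form, the S form and the undefined form apart at this carbon.

The second stereocentre is drawn with the same configuration in compound 1, compound 2 and compound 4, so these compounds cannot show whether its configuration matters as well. On these data alone, it also remains open whether the R and S forms would still sit this close with another group, such as a nitrile or a carboxylic acid, in place of the trifluoromethyl.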